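Two Aryl Groups on a Weakly Active Core

The source may report more compounds than this note shows. Statements on the series, on what has been measured and on what is new or still open speak of the compounds shown alone.

In a functional assay on HL-60 cells (Homo sapiens) for antiproliferative activity, with a stated time of 72 h (on this read-out higher numbers stand for weaker inhibition and lower numbers for stronger inhibition), compound 1 `Nc1ncnn2c([C@@H]3O[C@H](CO)[C@@H](O)[C@H]3O)cc(C#Cc3ccccc3)c12` gives > 100000 nM, which is a limit of the assay and not a number. Going by the values given here, compound 2 `Nc1ncnn2c([C@@H]3O[C@H](CO)[C@@H](O)[C@H]3O)cc(-c3ccc(F)cc3F)c12` gives 99300 nM, the only true number so far. Among the compounds with values here, the one measured step, a number no higher from compound 1 to compound 2 (the limit leaves the size open), has no readable size because of the limit of > 100000 nM in this assay, at which 1 of the 2 values shown sits.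

Compound 3 `Cc1ccccc1-c1cc([C@@H]2O[C@H](CO)[C@@H](O)[C@H]2O)n2ncnc(N)c12` keeps the shared core and the 3,4-dihydroxy-5-(hydroxymethyl)oxolan-2-yl group of compound 2. It changes one substituent, with 2-methylphenyl in place of 2,4-difluorophenyl on an aromatic carbon.

Within the data shown here, no measured step compares two aryl groups, and the only step available has an open size. Compound 2 at 99300 nM therefore remains the sole anchor, so no shift beyond the scatter is expected in this assay, in either direction. A result reported only as a limit would not be surprising.

The expected change is a 1.5-fold lower number from compound 2 to compound 3 (0.18 log units; within the scatter). For compound 3 the estimated value is 65000 nM, with an expected range from 15000 nM to 100000 nM.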

Compound 3, half-maximal inhibitory concentration: 48400 nM
The estimate for compound 3 lay 1.3-fold (0.13 log units) above the measured number; measured number inside the range.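

In this assay, going by these compounds alone, the exchange of 2,4-difluorophenyl for 2-methylphenyl gives a 2.1-fold lower number from compound 2 to compound 3 (0.31 log units; beyond the scatter), the first step with a readable size at this aromatic carbon, two ring bonds from the ring nitrogen. It shows that two aryl groups at this place can be told apart, although the step is modest. The exchange of 2-phenylethynyl for 2-methylphenyl gives an at least 2.0-fold lower number from compound 1 to compound 3 (0.31 log units; beyond the scatter), and the earlier step between compound 1 and compound 2 cannot be read, both being left open in size because of this limit: the limit of > 100000 nM in this assay, at which 1 of the 3 values shown sits.

The shown compounds cannot separate the gain of the methyl group from the loss of the two fluorine atoms, so an unsubstituted phenyl ring or a phenyl ring bearing a methoxy group would be needed to tell them apart. On these data alone, the 3,4-dihydroxy-5-(hydroxymethyl)oxolan-2-yl group is the same in all three compounds, and it remains open how far a smaller group at this place, such as an amine or a short alkyl chain, would move the number.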